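The compounds below may be only part of what the source reports. "The series", "measured", "known", "first", "only" and "open" are said of these compounds alone.

Measured in an ADME assay on the whole organism (strain Fischer) for pharmacokinetics, with Rattus norvegicus as the target, at a dose of 30 mg/kg by the oral route; on this read-out higher numbers stand for higher oral bioavailability and lower numbers for lower oral bioavailability:
compound 1 `CCOC(=O)c1ccc(Cl)cc1O[C@H]1CC[C@H]2CN[C@H](C(=O)OCC)C[C@H]2C1` gives 32.9%
compound 2 `CCOC(=O)c1ccc(-c2ccccc2)cc1O[C@H]1CC[C@H]2CN[C@H](C(=O)OCC)C[C@H]2C1` gives 22.2%
compound 3 `CCOC(=O)c1ccccc1S[C@H]1CC[C@H]2CN[C@H](C(=O)OCC)C[C@H]2C1` gives 38.8%

Compound 2 stands lowest of the three numbers; compound 1 sits beyond the scatter above it, and compound 3 further still. Within the data shown here, the one measured step that bears on the next change is a number 10.7 percentage points lower from compound 1 to compound 2 (beyond the scatter). Compound 4 `CCOC(=O)c1ccccc1O[C@H]1CC[C@H]2CN[C@H](C(=O)OCC)C[C@H]2C1` is not yet measured; it differs from compound 2 by hydrogen in place of phenyl on an aromatic carbon. Among the measured compounds shown here, no measured pair sets hydrogen directly against phenyl, but compound 3, which carries neither chloro nor phenyl on that ring, gives 38.8%. Taking the phenyl away is therefore expected to move this assay upward, by about a number 11.8 percentage points higher from compound 2 to compound 4 (beyond the scatter), a step beyond the scatter. Compound 4 is estimated at 34%, range 22% to 46%.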

Compound 4, oral bioavailability: 75.3%
Compound 4: the middle estimate sits 41.3 percentage points below what was measured; the whole stated range lies below it.
By their numbers in this assay, from the lowest: compound 2; then compounds 1 and 3 (each within the scatter of the next); then compound 4.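

In this assay, hydrogen in place of phenyl on this aromatic carbon gives a number 53.1 percentage points higher from compound 2 to compound 4 (beyond the scatter), and hydrogen in place of chloro gives a number 42.4 percentage points higher from compound 1 to compound 4 (beyond the scatter). At this carbon, para to an ethoxycarbonyl group, both substituents therefore go with a much lower number than hydrogen, and the earlier chloro-to-phenyl step covered only a small part of that span. Nothing measured here accounts for the size of these steps.

Going by these compounds, whether a methyl, a fluoro or an amine at this carbon keeps the high number remains open. So does whether the gain survives with a carboxylic acid in place of the ethoxycarbonyl group.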